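Methyl for methoxy on the aryl ring of compound 3

The source may hold more compounds than are shown below. What is called first, only, known or untested is meant among the compounds shown, and "the series" means these compounds.

Compound 3 `CCCCNC(=O)NS(=O)(=O)c1ccc(-n2nc(-c3ccc(OC)cc3)ccc2=O)cc1` gives the lowest of the three numbers in a functional assay on the whole organism (blood, strain Wistar albino) for inhibition, with Rattus norvegicus as the target, read by colorimetric assay, with stated times of 15 min and 90 min, at a dose of 20 mg/kg by the oral route (on this read-out higher numbers stand for more inhibition at the one dose given (going by the name of the read-out) and lower numbers for less inhibition), at 43.7%. Its nearest neighbour is compound 2 `O=C(NC1CCCCC1)NS(=O)(=O)c1ccc(-n2nc(-c3ccccc3)ccc2=O)cc1`, which gives 52.1% in this assay, a gap within the scatter. The furthest is compound 1 `CCCCNC(=O)NS(=O)(=O)c1ccc(-n2nc(-c3ccccc3)ccc2=O)cc1`, which gives 67.4% in this assay; that step is a number 23.7 percentage points lower from compound 1 to compound 3 (beyond the scatter). The step of a number 15.3 percentage points lower from compound 1 to compound 2 (beyond the scatter) concerns a different part of the molecule and does not bear on the present change.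

Compound 4 `CCCCNC(=O)NS(=O)(=O)c1ccc(-n2nc(-c3ccc(C)cc3)ccc2=O)cc1` differs from compound 3 by methyl in place of methoxy on an aromatic carbon. Going by the values given here, no measured step places methyl at this carbon; the only relevant step is the one from compound 1 to compound 3, in which methoxy entering for hydrogen lowered the read-out beyond the scatter. Replacing methoxy with methyl is expected to recover part of that loss, so a modest rise is expected, a number 9.3 percentage points higher from compound 3 to compound 4 (within the scatter). Compound 4 is therefore estimated to give 53% in this assay, within 38% to 68%.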

Compound 4, a percentage reported as inhibition, in the whole organism at one dose (the size of the read-out at that dose, not a potency): 86.6%
Beside the measured number, compound 4's estimate is 33.6 percentage points below it, outside the stated range (above it).
By their numbers in this assay, from the lowest: compounds 3 and 2 (each within the scatter of the next); then compound 1; then compound 4.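

Going by these compounds alone, the change from 4-methoxyphenyl to 4-methylphenyl gives a number 42.9 percentage points higher from compound 3 to compound 4 (beyond the scatter) in this assay, so this aromatic carbon has a larger effect on the read-out than the earlier compounds revealed. Those compounds showed only a fall on substitution here, whereas methyl in place of hydrogen gives a number 19.2 percentage points higher from compound 1 to compound 4 (beyond the scatter), so methyl and methoxy move the number in opposite directions from compound 1. Nothing available accounts for this difference between the two groups.

Going by these compounds, whether the rise extends to other groups at this carbon, such as ethyl, chlorine or hydroxyl, remains open. Also open, on these data alone, is whether methyl has the same effect when cyclohexyl replaces butyl on the amide-type nitrogen, as it does in compound 2.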